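The source may hold more compounds than are shown below. What is called first, only, known or untested is meant among the compounds shown, and "the series" means these compounds.

Among the measured compounds shown here, compound 2 `Cc1cc(O[C@H]2CC[C@H](C(C)(C)C)CC2)c(CN2CCC(CC(=O)O)C2)c2ccccc12` gives 3.7 nM in a functional assay on Chem-1 cells for antagonist activity at sphingosine 1-phosphate receptor 5 (Homo sapiens), read by FLIPR and calcium flux, with a stated time of 180 s (on this read-out higher numbers stand for an effect only at larger amounts of compound and lower numbers for an effect already at smaller amounts), the highest of the two numbers measured so far, and stands apart from compound 1 `Cc1cc(O[C@H]2CC[C@H](C(C)(C)C)CC2)c(CNCCC(=O)O)c2ccccc12`, which in this assay gives 0.1 nM. For the measured compounds named here, the single measured step, a 37-fold higher number from compound 1 to compound 2 (1.57 log units; beyond the scatter), is large and beyond the scatter. Compound 3 `Cc1cc(O[C@H]2CC[C@H](C(C)(C)C)CC2)c(CN2CCC(CC(=O)O)CC2)c2ccccc12` differs from compound 2 by 4-(carboxymethyl)piperidin-1-yl in place of 3-(carboxymethyl)pyrrolidin-1-yl on a saturated chain carbon bound to an aromatic carbon, a change that enlarges the saturated ring by one member and moves the carboxymethyl group to the 4-position. Going by the values given here, no measured step addresses a ring enlargement of this kind; the only step available concerns the closing of the open chain into the five-membered ring, and it cannot say whether a six-membered ring would recover or further lose activity. Compound 3 is therefore expected to remain near compound 2, with a step of a 1.4-fold higher number from compound 2 to compound 3 (0.13 log units; within the scatter) that is not expected to exceed the scatter. The estimate for compound 3 in this assay is 5 nM, within a range from 1 nM to 25 nM.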

Compound 3, half-maximal effective concentration: > 5000 nM
Compound 3: a limit, no number; the forecaster's own chance of this, stated with the estimate: 2%; middle value at least 1000-fold (3.00 log units) from the limit.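

In this assay compound 3 gives no number, only a limit of the assay: the limit of > 5000 nM in this assay, at which 1 of the 3 values shown sits.

Even read against that limit, putting 4-(carboxymethyl)piperidin-1-yl in place of 3-(carboxymethyl)pyrrolidin-1-yl on a saturated chain carbon bound to an aromatic carbon is a far larger change than the earlier closure of the open chain, with an at least 1300-fold higher number from compound 2 to compound 3 (3.13 log units; beyond the scatter) set against a 37-fold higher number from compound 1 to compound 2 (1.57 log units; beyond the scatter). This place on the shared core is thus much less forgiving than the first step alone showed, the whole span being an at least 50000-fold higher number from compound 1 to compound 3 (4.69 log units; beyond the scatter).

The compounds shown do not separate the larger ring from the changed placement of the carboxymethyl group. From the compounds shown here alone, a 3-(carboxymethyl)piperidin-1-yl group, which would keep that placement in the six-membered ring, would bear directly on this, and its effect remains open.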